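Adding the 4-nitrophenyl back onto compound 3's ring nitrogen

The source may hold more compounds than are shown below. What is called first, only, known or untested is meant among the compounds shown, and "the series" means these compounds.

Measured so far:
compound 1 `Cc1ccc(C2=NN(c3ccc([N+](=O)[O-])cc3)C(c3cn(-c4ccccc4)nc3-c3ccc(Cl)c(Cl)c3)C2)cc1`: 72.5%
compound 2 `Cc1ccc(C2=NNC(c3cn(-c4ccccc4)nc3-c3ccc(Cl)c(Cl)c3)C2)cc1`: 56.5%
compound 3 `Clc1ccc(C2=NNC(c3cn(-c4ccccc4)nc3-c3ccc(Cl)c(Cl)c3)C2)cc1`: 45.8%

All three numbers come from a functional assay on the whole organism (strain Wistar) for inhibition, with Rattus norvegicus as the target, read by paw edema, with stated times of 30 min and 60 min, at a dose of 50 mg/kg by the oral route; on this read-out lower numbers stand for less inhibition and higher numbers for more inhibition at the one dose given (going by the name of the read-out). Compound 3 stands lowest of the three: compound 2 lies nearest, by a number 10.7 percentage points lower from compound 2 to compound 3 (beyond the scatter), and compound 1 furthest. The unmeasured compound 4 `O=[N+]([O-])c1ccc(N2N=C(c3ccc(Cl)cc3)CC2c2cn(-c3ccccc3)nc2-c2ccc(Cl)c(Cl)c2)cc1` differs from compound 3 in one place: 4-nitrophenyl in place of hydrogen on an amine nitrogen in a ring.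

Within the data shown here, one measured step bears directly on this change, in the opposite direction: a number 16 percentage points lower from compound 1 to compound 2 (beyond the scatter), with the other step, a number 10.7 percentage points lower from compound 2 to compound 3 (beyond the scatter), only showing that the pair of compound 3 and compound 4 sits on a different substituent than the pair of compound 1 and compound 2. Reversing the removal of the 4-nitrophenyl is therefore expected to give a gain in this assay of about the same size, beyond the scatter, so the step of a number 16.2 percentage points higher from compound 3 to compound 4 (beyond the scatter) is the estimate. Compound 4 is expected to reach about 62% in this assay, within a range from 52% to 72%.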

Compound 4, a percentage reported as inhibition, in the whole organism at one dose (the size of the read-out at that dose, not a potency): 57.3%
For compound 4 the middle estimate is 4.7 percentage points above the measured one; measured number inside the range.
By their numbers in this assay, from the lowest: compound 3; then compounds 2 and 4 (each within the scatter of the next); then compound 1.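

In this assay, adding the 4-nitrophenyl on the amine nitrogen in the ring also gives a gain on the second core, a change of a number 11.5 percentage points higher from compound 3 to compound 4 (beyond the scatter), so the effect no longer rests on a single pair: the same change on two cores in this assay, a number 16 percentage points lower (beyond the scatter) from compound 1 to compound 2 and a number 11.5 percentage points lower (beyond the scatter) from compound 4 to compound 3, 4.5 percentage points apart, within the scatter of two such steps

The chloro in place of methyl on an aromatic carbon likewise repeats with the 4-nitrophenyl present, a change of a number 15.2 percentage points lower from compound 1 to compound 4 (beyond the scatter): the same change on two cores in this assay, a number 10.7 percentage points lower (beyond the scatter) from compound 2 to compound 3 and a number 15.2 percentage points lower (beyond the scatter) from compound 1 to compound 4, 4.5 percentage points apart, within the scatter of two such steps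

Across these four compounds, the size of each change therefore shows no clear dependence on the other.

The compounds shown carry only hydrogen or 4-nitrophenyl on this nitrogen, so it remains open whether the gain needs the nitro group or would also appear with a plain phenyl or an acetyl. Each compound is also read at a single dose, which leaves potency open.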